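A Sulfonamide Arm in Place of a Fluorobenzyl

A few compounds are considered here, and "the series" means these few. Any claim that something is new, unique, unknown or untested is made for them only; others in the source may bear on it.

Of the compounds shown here, two that share one core have been measured in a functional assay on MGC-803 cells (Homo sapiens) for antiproliferative activity, read by MTT assay, with a stated time of 48 h; a higher number here means a weaker inhibitor, a lower number a stronger inhibitor. Compound 1, `c1ccc(Cn2cc(Cc3nnc(-c4ccccc4)c(-c4ccccc4)n3)nn2)cc1`, gives 11400 nM in this assay. Compound 2, `Fc1ccc(Cn2cc(CSc3nnc(-c4ccccc4)c(-c4ccccc4)n3)nn2)cc1`, gives 7590 nM in this assay. Compound 2 has the lower of the two numbers, but its gap to compound 1 lies within the usual scatter, so the two cannot be told apart on these data.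

Compound 3, `NS(=O)(=O)c1ccc(-n2cc(CSc3nnc(-c4ccccc4)c(-c4ccccc4)n3)nn2)cc1`, differs from compound 2 in one place: 4-sulfamoylphenyl in place of 4-fluorobenzyl on an aromatic nitrogen. Among the measured compounds shown here, no pair of measured compounds shows what such a swap does to the numbers, so there is no step to lean on. The change is expected to move the number only modestly, in either direction, and not clearly beyond the scatter.

Compound 3 is therefore estimated at 7000 nM in this assay, with a range from 1800 nM to 28000 nM. This estimate means a step of a 1.1-fold lower number from compound 2 to compound 3 (0.04 log units; within the scatter) that stays within the scatter.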

Compound 3, half-maximal inhibitory concentration: > 100000 nM
Compound 3 was reported as a limit (the forecaster's own chance of this, stated with the estimate: 10%); middle value at least 14-fold (1.15 log units) from the limit.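

In this assay, 4-sulfamoylphenyl in place of 4-fluorobenzyl on this aromatic nitrogen brings an at least 13-fold higher number from compound 2 to compound 3 (1.11 log units; beyond the scatter). Among the compounds shown here, for compound 3, the value > 100000 nM is a limit of the assay and not a number: the limit of > 100000 nM in this assay, at which 1 of the 3 values shown sits. Compound 1 and compound 2 offered no step to read, whereas this one shows that the group on this nitrogen can decide whether the series keeps any measurable activity in this assay.

The swap changes two things at once, benzyl to phenyl and fluorine to a sulfonamide, and the compounds shown cannot say which of the two carries the loss. A 4-sulfamoylbenzyl group or a 4-fluorophenyl group on the same nitrogen would pull these apart, and a 4-aminophenyl or 4-carboxyphenyl group would test other substituents on the phenyl ring.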